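The source may report more compounds than this note shows. Statements on the series, on what has been measured and on what is new or still open speak of the compounds shown alone.

Three compounds share the same core and differ only in the ring attached to the outer aromatic ring. Compound 1 `CCC(C)(C)Cc1c[nH]c(CCc2ccc(-c3ccncc3)cc2)n1` carries a pyridin-4-yl group there, and in a functional assay on HEK293 cells for agonist activity at Bombesin receptor subtype-3 (Mus musculus), read by luminescence and calcium flux, with a stated time of 10 min (a higher number here means that more compound is needed for the effect, a lower number that less compound is needed), compound 1 gives 15 nM. Compound 2 `CCC(C)(C)Cc1c[nH]c(CCc2ccc(-n3ncnn3)cc2)n1` carries a 2H-tetrazol-2-yl group, and in this assay compound 2 gives 25 nM. Compound 3 `CCC(C)(C)Cc1c[nH]c(CCc2ccc(-c3csnn3)cc2)n1` carries a 1,2,3-thiadiazol-4-yl group, and in this assay compound 3 gives 11 nM, the lowest of the three numbers. The steps of a 1.4-fold lower number from compound 1 to compound 3 (0.13 log units; within the scatter) and a 1.7-fold higher number from compound 1 to compound 2 (0.22 log units; within the scatter) lie within the scatter, while the step of a 2.3-fold lower number from compound 2 to compound 3 (0.36 log units; beyond the scatter) is the only one beyond it; all three rings thus land close together.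

Compound 4 `CCC(C)(C)Cc1c[nH]c(CCc2ccc(-c3cccnc3C(=O)O)cc2)n1` is the next analogue: 2-carboxypyridin-3-yl in place of 1,2,3-thiadiazol-4-yl on an aromatic carbon. Within the data shown here, none of the measured steps involves a carboxylic acid, so they bear on this change only loosely, showing that swapping one small ring for another moves the number little. With that unfamiliar acid the uncertainty is wide, and compound 4 is expected to give 30 nM, with a range from 8 nM to 120 nM. This estimate means the step of a 2.7-fold higher number from compound 3 to compound 4 (0.44 log units; beyond the scatter).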

Compound 4, half-maximal effective concentration: 14 nM
Compound 4: the middle estimate sits 2.1-fold (0.33 log units) above what was measured; the measured number falls inside the stated range.
By their numbers in this assay, from the lowest: compounds 3, 4, 1 and 2 (each within the scatter of the next, the first and the last beyond it).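

Compound 4 places a larger group at this position: 2-carboxypyridin-3-yl has 9 heavy atoms against 5 in 1,2,3-thiadiazol-4-yl, and it brings a hydrogen-bond donor, yet this assay shows little response (a 1.3-fold higher number from compound 3 to compound 4 (0.10 log units; within the scatter)). The other two comparisons agree (a 1.8-fold lower number from compound 2 to compound 4 (0.25 log units; within the scatter); a 1.1-fold lower number from compound 1 to compound 4 (0.03 log units; within the scatter)), so this site, para to a large group, holds a ring bearing a carboxylic acid as well as any of the three earlier rings, a wider range than those rings alone could show. Nothing at hand explains why such different rings give such close numbers. Going by these compounds, whether the acid contributes anything remains open, since no pyridine ring here lacks it at the same place on an otherwise matching compound. A methyl ester, an amide or an amine in its place would test this.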